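The source may report more compounds than this note shows. Statements on the series, on what has been measured and on what is new or still open speak of the compounds shown alone.

Measured so far in an ADME assay on Vero cells (Chlorocebus sabaeus) for cytotoxicity, read by resazurin assay, with a stated time of 3 days; on this read-out lower numbers stand for stronger inhibition and higher numbers for weaker inhibition:
compound 1 `COc1ccc(C(=O)Nc2cc3nc(C4CCCCC4)[nH]c3cc2N2CCCC2)cc1`, > 100 ug/mL
compound 2 `CCN(CC)c1cc2[nH]c(C3CCCCC3)nc2cc1NC(=O)c1cnccn1`, > 100 ug/mL
compound 3 `CN(C)c1cc2[nH]c(C3CCCCC3)nc2cc1NC(=O)c1cccc(Br)c1`, > 100 ug/mL

In this assay compound 2 gives > 100 ug/mL, which is a limit of the assay and not a number. Compound 1 gives > 100 ug/mL, also a limit. Compound 3 gives > 100 ug/mL, a limit as well. So compound 2 stands where every measured compound stands, at the limit of > 100 ug/mL in this assay, at which 3 of the 3 values shown sit, and no measured compound gives a number.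

Compound 4 `CCc1ccc(C(=O)Nc2cc3nc(C4CCCCC4)[nH]c3cc2N(CC)CC)cc1` has not yet been measured. It differs from compound 2 in one place: 4-ethylphenyl in place of pyrazin-2-yl on a carbonyl carbon. Going by the values given here, no step between two measured compounds is available to compare this change against, so the expectation rests on the limit alone. Because the limit of > 100 ug/mL in this assay, at which 3 of the 3 values shown sit, holds for all three measured compounds, compound 4 is expected to stay at that limit too, with no step beyond the scatter. The expected step from compound 2 to compound 4 in this assay is a step that the limit leaves unreadable from compound 2 to compound 4. For compound 4 the estimate in this assay is 130 ug/mL, with a range from 60 ug/mL to 300 ug/mL.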

Compound 4, half-maximal inhibitory concentration: > 100 ug/mL
Compound 4: no number, only a limit (the forecaster's own chance of this, stated with the estimate: 80%); the middle value is on the limit's open side.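

In this assay compound 4 gives > 100 ug/mL, which is a limit of the assay and not a number. Compound 2 also sits at a limit, and no step can be read from compound 2 to compound 4. The compounds shown leave open at what concentration any of them would harm these cells: the limit of > 100 ug/mL in this assay, at which 4 of the 4 values shown sit.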